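Dichlorophenyl sulfonamide analogs of a shared core

The compounds below may be only part of what the source reports. "The series", "measured", "known", "first", "only" and "open" are said of these compounds alone.

Compound 1 `COc1cc(C)ccc1S(=O)(=O)NC1=NCCN1C(=S)SN1CCn2c1nsc2=S`: >= 20000 nM
Compound 2 `O=S(=O)(NC1=NCCN1C(=S)SN1CCn2c1nsc2=S)c1ccc(Cl)c(Cl)c1`: >= 20000 nM

Of the compounds shown here, two have been measured in a functional assay on KYSE-510 cells (Homo sapiens) for antiproliferative activity, read by crystal violet staining, with a stated time of 96 h (a higher number here means a weaker inhibitor of growth, a lower number a stronger inhibitor of growth), so far, and both sit at the edge of what the assay can report. In this assay compound 1 gives >= 20000 nM, which is a limit of the assay and not a number. In the same assay compound 2 gives >= 20000 nM, again a limit rather than a number. The step that the two limits leave unreadable from compound 1 to compound 2 is therefore unreadable, as the two limits leave its size open; what can be said is only that (the limit of >= 20000 nM in this assay, at which 2 of the 2 values shown sit).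

Compound 3 `O=S(=O)(NC1=NCCN1C(=S)SN1CCn2c1nsc2=S)c1cc(Cl)cc(Cl)c1` is not yet measured. It differs from compound 1 by 3,5-dichlorophenyl in place of 2-methoxy-4-methylphenyl on a sulfonyl sulfur. Going by the values given here, the only measured step that bears on this change, a step that the two limits leave unreadable from compound 1 to compound 2, likewise replaces the 2-methoxy-4-methylphenyl with a dichlorophenyl and gave no readable number. With both known compounds at the limit, compound 3 is expected to stay at the same limit, so that the step of a number no higher from compound 1 to compound 3 (the limit leaves the size open) is estimated to be none beyond the scatter. Compound 3 is therefore expected to give about 20000 nM, within a range of 8000 nM to 60000 nM.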

Compound 3, concentration for 50% growth inhibition: >= 20000 nM
Compound 3: no number, only a limit; the forecaster's own chance of this, stated with the estimate: 80%; the middle value lies on the limit itself.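

In this assay compound 3 gives >= 20000 nM, a limit of the assay and not a number. The steps to compound 3 from compound 1 and from compound 2 therefore cannot be read: the limit of >= 20000 nM in this assay, at which 3 of the 3 values shown sit. The compounds shown leave open how strongly each inhibits growth, and whether changing the group on the sulfonyl sulfur makes any difference.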